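This account rests on a few compounds, and the source may have more. Where it says the series, first, only, none or still open, it means among the compounds named here.

In a functional assay on Raji cells (Homo sapiens) for cytotoxicity, with a stated time of 72 h (a lower number here means that less compound is needed, a higher number that more compound is needed for the effect), compound 1 `C=C[C@@](C)(/C=C/c1ccc(O)cc1)CC/C=C(\C)C(=O)OCC` gives > 26000 nM, which is a limit and not a number. Compound 2 `C=C[C@@](C)(/C=C/c1ccc(O)cc1)CC/C=C(C)/C=C/C(=O)OCC` gives > 26000 nM, again a limit and not a number. Compound 2 thus has no number of its own, and the record so far is the limit of > 26000 nM in this assay, at which 2 of the 2 values shown sit. Among the measured compounds shown here, the only measured step, a step that the two limits leave unreadable from compound 1 to compound 2, has no size that could be carried forward. Compound 3 `C=C[C@@](C)(/C=C/c1ccc(O)cc1)CC/C=C(C)/C=C/C(=O)OCc1ccccc1` keeps the core of compound 2 and differs in one place: phenyl in place of methyl on a saturated chain carbon bound to an oxygen next to a carbonyl group. This is phenyl in place of methyl on a saturated chain carbon bound to an oxygen next to a carbonyl group, so ethoxycarbonyl becomes benzyloxycarbonyl. For the measured compounds named here, no measured step touches this place, so the data give neither a size nor a direction for it. The expected step, an at least 1.3-fold lower number from compound 2 to compound 3 (0.11 log units; that floor lies within the scatter), is therefore a cautious estimate: small and toward a lower number if a number is reported at all, with another limit quite possible. For compound 3 the estimated value is 20000 nM, with an expected range of 7000 nM to 45000 nM.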

Compound 3, half-maximal effective concentration: > 26000 nM
Compound 3: only a limit was reported; the forecaster's own chance of this, stated with the estimate: 60%; middle value at least 1.3-fold (0.11 log units) away from the limit.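

In this assay compound 3 gives > 26000 nM, which is a limit and not a number. Compound 2 also carries only a limit, so no step can be read between compound 2 and compound 3. The compounds shown leave open what number any of them would give and whether phenyl in place of methyl changes it. The record now reads: the limit of > 26000 nM in this assay, at which 3 of the 3 values shown sit.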